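Notes on the step from compound 1 to compound 4

The compounds below may be only part of what the source reports. "The series", "measured", "known", "first", "only" and "open" are said of these compounds alone.

Values so far in an ADME assay on NIH3T3 cells (Mus musculus) for cytotoxicity, read by MTT assay, with a stated time of 24 h (a higher number here means a weaker inhibitor, a lower number a stronger inhibitor), are these
- compound 1 `O=C(CSc1nnnn1-c1ccccc1)N/N=c1/scc(-c2ccc(Br)cc2)n1-c1ccccc1` gives 433 ug/mL
- compound 2 `COc1ccc(-c2cs/c(=N/NC(=O)CSc3nnnn3-c3ccccc3)n2-c2ccccc2)cc1` gives 11.7 ug/mL
- compound 3 `O=C(CSc1nnnn1-c1ccccc1)N/N=c1/scc(-c2ccc(F)cc2)n1-c1ccccc1` gives 207 ug/mL

Compound 1 stands highest of the three, with compound 3 nearest and compound 2 furthest. Compound 4 `O=C(CSc1ncccn1)N/N=c1/scc(-c2ccc(Br)cc2)n1-c1ccccc1` keeps the bromo group of compound 1 and changes one place: pyrimidin-2-yl in place of 1-phenyl-1H-tetrazol-5-yl on a sulfur. Within the data shown here, no measured step touches that place. All three concern the aromatic substituent: a 37-fold lower number from compound 1 to compound 2 (1.57 log units; beyond the scatter) for methoxy in place of bromo, a 2.1-fold lower number from compound 1 to compound 3 (0.32 log units; beyond the scatter) for fluoro in place of bromo, and an 18-fold higher number from compound 2 to compound 3 (1.25 log units; beyond the scatter) for fluoro in place of methoxy. They show that one change in this series can move this assay by anything from a modest to a large step, so they bear on size only, and only indirectly. Among the measured compounds shown here, compound 1, at 433 ug/mL as the highest number so far, leaves a lower number as the likelier direction, though a step the other way is not excluded. The expected step is a 2.9-fold lower number from compound 1 to compound 4 (0.46 log units; beyond the scatter) as a rough estimate. Compound 4 is estimated at 150 ug/mL with 30 ug/mL to 600 ug/mL as the expected range.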

Compound 4, half-maximal inhibitory concentration: 273 ug/mL
Beside the measured number, compound 4's estimate is 1.8-fold (0.26 log units) below it; the range from low to high includes it.
By their numbers in this assay, from the lowest: compound 2; then compounds 3, 4 and 1 (each within the scatter of the next, the first and the last beyond it).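

In this assay, among these compounds, the replacement of 1-phenyl-1H-tetrazol-5-yl by pyrimidin-2-yl on the sulfur gives a 1.6-fold lower number from compound 1 to compound 4 (0.20 log units; within the scatter), the first reading at this place. With the bromo group held fixed, a substituent with one six-membered aromatic ring in place of the earlier two-ring group leaves the read-out indistinguishable from that of compound 1, whereas on the aromatic carbon methoxy in place of bromo gave a 37-fold lower number from compound 1 to compound 2 (1.57 log units; beyond the scatter). Nothing available explains why this exchange on the sulfur registers so little in the assay.

This is a single exchange on a single background, so it does not establish that the place is generally insensitive, nor whether pyrimidin-2-yl would behave the same alongside the methoxy group of compound 2. Also open, from the compounds shown here alone, is whether a group of a different kind on the sulfur, such as a saturated alkyl chain, an amine or a carboxylic acid, would stay as close to compound 1.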